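Swapping Methylcarbamoyl for Amino on a Shared Core

The source may report more compounds than this note shows. Statements on the series, on what has been measured and on what is new or still open speak of the compounds shown alone.

Measured compounds:
compound 1 `CNC(=O)c1ccc(-c2cc(C(=O)N[C@H]3CCCNC3)c(NC(N)=O)s2)cc1` gives 4300 nM in a functional assay on HT-29 cells (Homo sapiens); a lower number here means that less compound is needed, a higher number that more compound is needed for the effect
compound 2 `CNCCNC(=O)c1cc(-c2ccccc2)sc1NC(N)=O` gives 580 nM in this assay

Compound 1 has the higher of the two numbers recorded so far in this assay. Among the measured compounds shown here, its nearest neighbour, compound 2, differs from it in several places at once, so the two values show only that compound 2 sits well below compound 1, beyond the usual scatter, and say nothing about any single change.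

The next compound, compound 3 `NC(=O)Nc1sc(-c2ccc(N)cc2)cc1C(=O)N[C@H]1CCCNC1`, differs from compound 1 by amino in place of methylcarbamoyl on an aromatic carbon. For the measured compounds named here, no pair of measured compounds isolates this change, so there is no direct precedent. The expected step from compound 1 to compound 3 in this assay is small and could go either way, estimated as a 1.4-fold lower number from compound 1 to compound 3 (0.16 log units; within the scatter). Compound 3 is therefore expected to give about 3000 nM, within a range from 900 nM to 10000 nM.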

Compound 3, half-maximal effective concentration: 920 nM
Compound 3: the middle estimate sits 3.3-fold (0.51 log units) above what was measured, within the range that was stated.
By their numbers in this assay, from the lowest: compounds 2 and 3 (each within the scatter of the next); then compound 1.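

In this assay, among the compounds shown here, compounds 1 and 3 form the first pair that differs in one place only, and the step is a 4.7-fold lower number from compound 1 to compound 3 (0.67 log units; beyond the scatter), which lies beyond the scatter. This shows that the group on this aromatic carbon, para to a large group, affects the result, and that methylcarbamoyl can be replaced by the single-atom amino group without needing more compound for the effect. No measurement presented here explains why the number falls.

One pair cannot show whether the fall comes from adding amino or from removing methylcarbamoyl, so a plain hydrogen, a hydroxyl group or a carboxylic acid at this position would each be informative. Also open, on these data alone, is whether amino would give a similar step with the different amide chain of compound 2.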